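A few compounds are considered here, and "the series" means these few. Any claim that something is new, unique, unknown or untested is made for them only; others in the source may bear on it.

Of the compounds shown here, three have been measured so far in a functional assay on SW1573 cells (Homo sapiens) for inhibition, read by sulforhodamine B assay, with a stated time of 48 h; on this read-out lower numbers stand for stronger inhibition of growth and higher numbers for weaker inhibition of growth. Compound 1, `CC(=O)OC/C(=C/c1ccc(Cl)cc1)C(=O)c1ccc(Cl)cc1`, gives 5300 nM in this assay. Compound 2, `CC(=O)OC/C(=C/c1ccc(Cl)cc1Cl)C(=O)c1ccc(Cl)cc1`, differs from compound 1 by chloro in place of hydrogen on an aromatic carbon; in this assay compound 2 gives 21000 nM. That single change produced a 4.0-fold higher number from compound 1 to compound 2 (0.60 log units; beyond the scatter), a step that made compound 2 a weaker inhibitor of cell growth than compound 1.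

Compound 3, `C=C(C/C(=C\c1ccccc1)C(=O)c1ccccc1)C(=O)c1ccccc1`, is built on a different core. In this assay compound 3 gives 3000 nM. The difference between the core of compound 3 and the core of compound 1 is not broken down here, so nothing can be said about which feature of the core accounts for the gap between the two values.

Compound 4, `C=C(C/C(=C\c1ccc(Cl)cc1)C(=O)c1ccccc1)C(=O)c1ccccc1`, has not yet been measured. It differs from compound 3 by chloro in place of hydrogen on an aromatic carbon. For the measured compounds named here, this is the same kind of change as the one from compound 1 to compound 2, but the place is not the same: in compound 2 the chloro sits ortho to a large group and meta to a chloro group, whereas in compound 4 it sits para to a large group, on a ring that carries no other chloro. Going by the values given here, because the only measured step of this kind, a 4.0-fold higher number from compound 1 to compound 2 (0.60 log units; beyond the scatter), weakened growth inhibition, a small weakening is expected for compound 4 as well, although the different place and core leave the direction uncertain. The step expected from compound 3 to compound 4 is a 1.3-fold higher number from compound 3 to compound 4 (0.12 log units; within the scatter), giving an estimate for compound 4 of 4000 nM, likely between 1500 nM and 12000 nM.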

Compound 4, concentration for 50% growth inhibition: 6100 nM
Compound 4: the middle estimate sits 1.5-fold (0.18 log units) below what was measured, within the range that was stated.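

In this assay the new step is a 2.0-fold higher number from compound 3 to compound 4 (0.31 log units; beyond the scatter) and so, as with the earlier pair, swapping a hydrogen for a chloro on an aromatic ring goes with weaker inhibition of growth. Setting the two steps side by side shows that the change points the same way on both cores and that the gap between their sizes is no larger than repeated measurements would be expected to produce: the same change on two cores in this assay, a 4.0-fold higher number (0.60 log units; beyond the scatter) from compound 1 to compound 2 and a 2.0-fold higher number (0.31 log units; beyond the scatter) from compound 3 to compound 4, 1.9-fold (0.29 log units) apart, within the scatter of two such steps. For the compounds shown here, this does not show that the step has a fixed size or that it would carry to any further core, since there are only two pairs, the chloro stands in a different place in each, and neither pair says why the number rises.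

The compounds shown leave open whether a fluoro group, a methoxy group, an amine or a carboxylic acid, put where the chloro stands in the 4-chlorophenyl ring of compound 4, would raise the number as well or lower it. They also leave open what a chloro would do on the other two aromatic rings of compound 3.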